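Three measured compounds and one still to come

This account rests on a few compounds, and the source may have more. Where it says the series, first, only, none or still open, it means among the compounds named here.

Compound 1 `Cc1cc(C)cc(Cc2nc(SCc3ccc(C#N)cc3)[nH]c(=O)c2I)c1` in an ADME assay on HepG2 2.2.15 cells (Homo sapiens) for cytotoxicity, read by MTT assay, with a stated time of 72 h (on this read-out higher numbers stand for lower toxicity in this test and lower numbers for higher toxicity in this test), gives 43200 nM.
Compound 2 `O=c1[nH]c(SCc2ccc([N+](=O)[O-])cc2)nc(Cc2ccccc2)c1I` gives 52700 nM.
Compound 3 `Cc1cc(C)cc(Cc2nc(SCCc3ccc([N+](=O)[O-])cc3)[nH]c(=O)c2I)c1` gives 66600 nM.

Compound 2 stands second highest of the three numbers, and its gaps to compound 1 and to compound 3 both lie within the scatter, so the three compounds cannot be told apart on this read-out. Compound 4 `O=c1[nH]c(SCc2ccc([N+](=O)[O-])cc2)nc(Cc2cc(F)cc(F)c2)c1I` has not yet been measured in this assay. It differs from compound 2 in one place: 3,5-difluorophenyl in place of phenyl on a saturated chain carbon bound to an aromatic carbon. Among the compounds with values here, no pair of measured compounds isolates a change of this kind, and the three values give no direction to lean towards, so the expected step of a 1.1-fold lower number from compound 2 to compound 4 (0.02 log units; within the scatter) is none beyond the scatter. The half-maximal cytotoxic concentration of compound 4 is estimated at 50000 nM, with a range from 25000 nM to 100000 nM.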

Compound 4, half-maximal cytotoxic concentration: > 100000 nM
Compound 4 ended at the assay's limit (the forecaster's own chance of this, stated with the estimate: 10%); middle value at least 2.0-fold (0.30 log units) away from the limit.
By their numbers in this assay, from the lowest: compounds 1, 2 and 3 (each within the scatter of the next). At a limit, above all of these: compound 4.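

In this assay, 3,5-difluorophenyl in place of phenyl on a saturated chain carbon bound to an aromatic carbon gives an at least 1.8-fold higher number from compound 2 to compound 4 (0.27 log units; that floor lies within the scatter). For compound 4, > 100000 nM is a limit of the assay and not a number. This position therefore accepts the larger 3,5-difluorophenyl group with no sign of higher toxicity in this test, although the floor of the step alone does not separate the two compounds.

Going by these compounds, how far compound 4 lies past that limit stays open. So does the effect of an amine or a carboxylic acid at this place.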